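Triazole-bearing lactone and lactam series: step to compound 4

The compounds below may be only part of what the source reports. "The series", "measured", "known", "first", "only" and "open" are said of these compounds alone.

Measured so far:
- compound 1, `O=C1O/C(=C\Cn2cc(-c3ccccc3)nn2)C(OCc2ccccc2)=C1OCc1ccccc1`, a functional assay on PC-3 cells (Homo sapiens) for antiproliferative activity, read by MTT assay, with a stated time of 24 h; a lower number here means a stronger inhibitor, a higher number a weaker inhibitor: > 100000 nM
- compound 2, `O=C1O/C(=C\Cn2cc(Cc3ccccc3)nn2)C(OCc2ccccc2)=C1OCc1ccccc1`, this assay: 71300 nM
- compound 3, `O=C1NC(O)(CCn2cc(C3=CCCCC3)nn2)C(OCc2ccccc2)=C1OCc1ccccc1`, this assay: 67200 nM

The value of compound 1 is a limit of the assay and not a number (the limit of > 100000 nM in this assay, at which 1 of the 3 values shown sits). Among the two numbers, compound 3 has the lowest; its nearest neighbour is compound 2, and that gap lies within the scatter, so no order between compound 2 and compound 3 is claimed.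

Compound 4, `CC(C)(C)c1ccc(-c2cn(CCC3(O)NC(=O)C(OCc4ccccc4)=C3OCc3ccccc3)nn2)cc1`, remains to be measured. It differs from compound 3 in one place: 4-(tert-butyl)phenyl in place of cyclohex-1-en-1-yl on an aromatic carbon. For the measured compounds named here, the only measured step, an at least 1.4-fold lower number from compound 1 to compound 2 (0.14 log units; that floor lies within the scatter), changes the same position and stays within the scatter. It bears on the new step only loosely, since neither cyclohex-1-en-1-yl nor 4-(tert-butyl)phenyl appears in it. Given the small spread of the shown numbers, the step of a 1.2-fold higher number from compound 3 to compound 4 (0.08 log units; within the scatter) is expected to be modest, if anything toward a higher number. Compound 4 is therefore estimated at 80000 nM, with a range from 35000 nM to 200000 nM.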

Compound 4, half-maximal inhibitory concentration: 43000 nM
Compound 4: the middle estimate sits 1.9-fold (0.27 log units) above what was measured; the measured number falls inside the stated range.
By their numbers in this assay, from the lowest: compounds 4, 3 and 2 (each within the scatter of the next). At a limit, above all of these: compound 1.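

On an aromatic carbon of the five-membered aromatic ring with 3 nitrogen, 4-(tert-butyl)phenyl in place of cyclohex-1-en-1-yl gives, in this assay, a 1.6-fold lower number from compound 3 to compound 4 (0.19 log units; within the scatter), so no order between these two compounds is claimed. For the compounds shown here, this is the only measured step at this position on the core of compound 3, and it shows that going from 6 to 10 heavy atoms, and from a non-aromatic to an aromatic six-membered ring, leaves the number within the scatter. No measurement shown bears on a cause for this step.

From the compounds shown here alone, whether an amine or a carboxylic acid at this position would give a step beyond the scatter remains open. Also open, going by these compounds, is how 4-(tert-butyl)phenyl would read on the core of compound 2.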